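This account rests on a few compounds, and the source may have more. Where it says the series, first, only, none or still open, it means among the compounds named here.

Measured compounds: compound 1 `C=C(Br)C(=O)Nc1ccc(C(=O)/C=C/c2cccc(OC)c2)cc1` gives 500 nM in a functional assay on HeLa cells (Homo sapiens) for antiproliferative activity, with a stated time of 48 h; a higher number here means a weaker inhibitor, a lower number a stronger inhibitor; compound 2 `C=C(Br)C(=O)Nc1ccc(C(=O)/C=C/c2ccc(OC)c(OC)c2)cc1` gives 770 nM; compound 3 `Nc1ccc(C(=O)/C=C/c2ccccc2)cc1` gives 7700 nM.

Compound 3 stands highest of the three, with compound 2 its nearest neighbour. The difference between the core of compound 3 and the core of compound 1 is not broken down here.

The change from compound 1 to compound 2, (methoxy in place of hydrogen on an aromatic carbon), made the step of a 1.5-fold higher number from compound 1 to compound 2 (0.19 log units; within the scatter). Compound 4 `COc1ccccc1/C=C/C(=O)c1ccc(N)cc1` carries the same kind of change on the core of compound 3, (methoxy in place of hydrogen on an aromatic carbon); here the methoxy sits ortho to a large group, whereas in compound 2 it sits ortho to a methoxy group and para to a large group.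

Resting on the earlier step from compound 1 to compound 2, compound 4 is expected to move by a 1.2-fold lower number from compound 3 to compound 4 (0.07 log units; within the scatter) in this assay. Compound 4 is estimated at 6500 nM, between 2500 nM and 16000 nM.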

Compound 4, half-maximal inhibitory concentration: 7800 nM
For compound 4 the middle estimate is 1.2-fold (0.08 log units) below the measured one; low and high end bracket the measured number.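

In this assay, methoxy in place of hydrogen on the core of compound 3 gave a 1.0-fold higher number from compound 3 to compound 4 (0.01 log units; within the scatter). Set beside the earlier step, the change carried across the two cores with no difference that stands out from the scatter: the same change on two cores in this assay, a 1.5-fold higher number (0.19 log units; within the scatter) from compound 1 to compound 2 and a 1.0-fold higher number (0.01 log units; within the scatter) from compound 3 to compound 4, 1.5-fold (0.18 log units) apart, within the scatter of two such steps. Among these compounds, this rests on only two steps, however, and in compound 4 the methoxy sits ortho to a large group, unlike in compound 2, so it does not show that methoxy would behave alike at every place or on other cores.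

From the compounds shown here alone, it remains open whether a hydroxyl group, a fluorine atom or an ethoxy group in place of that hydrogen would behave alike. The compounds shown also do not break down the difference between the core of compound 3 and the core of compound 1.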